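The compounds below may be only part of what the source reports. "The series", "measured", "known", "first", "only" and "open" are said of these compounds alone.

Compound 1, `COc1cc(/C=C/C(=O)c2cccc(-n3cc(-c4ccccc4)nn3)c2)ccc1O`, gives 16800 nM in a functional assay on RAW264.7 cells (Mus musculus) for inhibition, with a stated time of 4 days; on this read-out higher numbers stand for weaker inhibition and lower numbers for stronger inhibition.
Compound 2, `C=C(C)c1cn(-c2cccc(C(=O)/C=C/c3ccc(OC)c(O)c3)c2)nn1`, gives 7760 nM in this assay.

Of these two numbers, compound 2 stands lowest: compound 1 sits at a higher number, and the gap between them lies beyond the usual scatter of the measurement. The next compound, compound 3, `COc1ccc(/C=C/C(=O)c2cccc(-n3cc(-c4ccccc4)nn3)c2)cc1O`, has not yet been measured in this assay. Compared with compound 2 it differs in one place: phenyl in place of 1-methylethenyl on an aromatic carbon.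

Within the data shown here, no step between two measured compounds covers this exact change, so the expectation rests on the two values above. Compound 1 also carries a phenyl on the five-membered aromatic ring with 3 nitrogen, and in this assay compound 1 gives 16800 nM, a weaker inhibition than compound 2. The step from compound 2 to compound 3 is therefore expected to run upward, toward weaker inhibition, by about a 1.9-fold higher number from compound 2 to compound 3 (0.29 log units; within the scatter), a size somewhat beyond the scatter. For compound 3 in this assay the estimate is 15000 nM, with a range from 6000 nM to 40000 nM.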

Compound 3, half-maximal inhibitory concentration: 1510 nM
Estimate against measurement, compound 3: 9.9-fold (1.00 log units) above; the measured number lies below the stated range.
By their numbers in this assay, from the lowest: compound 3; then compound 2; then compound 1.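

In this assay, the larger phenyl on an aromatic carbon of the five-membered aromatic ring with 3 nitrogen is accompanied by stronger inhibition than 1-methylethenyl, with a 5.1-fold lower number from compound 2 to compound 3 (0.71 log units; beyond the scatter). This step shows that, with the 3-hydroxy-4-methoxyphenyl group held constant, this position accepts a six-membered aromatic ring and the change favours inhibition. The arrangement of the hydroxy and methoxy groups on the other aryl ring also matters with phenyl held constant: 3-hydroxy-4-methoxyphenyl in place of 4-hydroxy-3-methoxyphenyl gives an 11-fold lower number from compound 1 to compound 3 (1.05 log units; beyond the scatter), so phenyl itself is not tied to weak inhibition, and compound 1 and compound 2 differ in two places, which leaves their gap unassigned to either change.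

Nothing available explains why either change moves the number in this direction.

The compounds shown leave open whether phenyl would still outdo 1-methylethenyl when the chain carries 4-hydroxy-3-methoxyphenyl, since only one of these two groups on the ring appears with that aryl group. They also leave open what a pyridyl ring, a cyclohexyl ring or a phenyl bearing a carboxylic acid would do at this aromatic carbon.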